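The source may hold more compounds than are shown below. What is called first, only, known or untested is meant among the compounds shown, and "the series" means these compounds.

Measured compounds:
Compound 1 `COc1ccc(NS(=O)(=O)c2ccc(-c3ccccn3)s2)cc1N1C[C@@H](C)N[C@@H](C)C1` gives 15.9 nM
Compound 2 `CCOc1ccc(N2C[C@@H](C)N[C@@H](C)C2)cc1NS(=O)(=O)c1ccc(-c2ccccn2)s1` gives 39.8 nM
Compound 3 `COc1ccc(N2C[C@@H](C)N[C@@H](C)C2)cc1NS(=O)(=O)c1ccc(-c2ccccc2)cc1` gives 6.31 nM

All three were tested in a functional assay for agonist activity at growth hormone secretagogue receptor type 1 (Homo sapiens), read by FLIPR; a higher number here means that more compound is needed for the effect, a lower number that less compound is needed. Among these numbers compound 3 stands lowest with 6.31 nM; compound 1 lies nearest to it and compound 2 furthest, and both gaps lie beyond the usual scatter, so compound 3 is the one of the three that needs the least compound for the effect.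

Compound 4 `COc1ccc(N2C[C@@H](C)N[C@@H](C)C2)cc1NS(=O)(=O)c1ccc(-c2ccc(C)o2)cc1` has not yet been measured. It differs from compound 3 in one place: 5-methylfuran-2-yl in place of phenyl on an aromatic carbon. Among the compounds with values here, no pair of measured compounds isolates a change of this kind, so nothing measured so far shows how large its effect is. The expectation for compound 4 is a modest step, within the scatter or only slightly beyond it, leaning toward a somewhat higher number, a 1.6-fold higher number from compound 3 to compound 4 (0.20 log units; within the scatter). Compound 4 is therefore estimated at 10 nM in this assay, with a range from 3 nM to 40 nM.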

Compound 4, half-maximal effective concentration: 0.794 nM
The estimate for compound 4 lay 13-fold (1.10 log units) above the measured number, outside the stated range (below it).
By their numbers in this assay, from the lowest: compound 4; then compound 3; then compound 1; then compound 2.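

In this assay, placing 5-methylfuran-2-yl instead of phenyl on the aromatic carbon para to a large group gives a 7.9-fold lower number from compound 3 to compound 4 (0.90 log units; beyond the scatter) and is the first change in a single place among these compounds. It shows that the group on this carbon can shift the number well beyond the scatter, even with the count of 6 heavy atoms unchanged, and that a six-membered aromatic ring of carbon only need not occupy this place. Nothing available here accounts for the size of this step.

The compounds shown leave open whether the five-membered ring or its methyl carries the step, which a plain furan-2-yl or an ethyl in place of the methyl would help to separate. They also leave open whether 5-methylfuran-2-yl would bring a similar step on the core of compound 1.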